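Phenyl Replaces Dichlorophenyl at the Pyrazole Nitrogen

The compounds below may be only part of what the source reports. "The series", "measured", "known", "first", "only" and "open" are said of these compounds alone.

Compound 1 `O=C(Nc1ccc(F)c(S(=O)(=O)N2CCOCC2)c1)c1cnn(-c2ccccc2)c1`: 8300 nM
Compound 2 `Cc1ccc(-c2nn(-c3ccc(Cl)cc3Cl)cc2C(=O)Nc2ccc(C)c(S(=O)(=O)N3CCOCC3)c2)cc1`: 14.1 nM

In an assay on isolated protein for antagonist activity at Bile acid receptor (Homo sapiens), read by TR-FRET, with a stated time of 20 min (on this read-out higher numbers stand for weaker inhibition and lower numbers for stronger inhibition), compound 2 gives 14.1 nM, the lowest of the two numbers shown, while compound 1 gives 8300 nM, a gap well beyond the scatter. Compound 3 `Cc1ccc(-c2nn(-c3ccccc3)cc2C(=O)Nc2ccc(C)c(S(=O)(=O)N3CCOCC3)c2)cc1` differs from compound 2 by phenyl in place of 2,4-dichlorophenyl on an aromatic nitrogen. Among the compounds with values here, no measured pair isolates this change, and compound 1 carries a plain phenyl on the same ring nitrogen but differs elsewhere too. A modest loss in this assay is expected, so that the step of a 4.3-fold higher number from compound 2 to compound 3 (0.63 log units; beyond the scatter) should lie beyond the scatter. Compound 3 is therefore estimated at 60 nM, within 15 nM to 300 nM.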

Compound 3, half-maximal inhibitory concentration: 47 nM
Beside the measured number, compound 3's estimate is 1.3-fold (0.11 log units) above it; the measured number falls inside the stated range.
By their numbers in this assay, from the lowest: compound 2; then compound 3; then compound 1.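

In this assay, within the data shown here, phenyl in place of 2,4-dichlorophenyl on the aromatic nitrogen gives a 3.3-fold higher number from compound 2 to compound 3 (0.52 log units; beyond the scatter), the first step that isolates this position. The two chlorines therefore contribute a modest but real part of the inhibition, and compound 3 remains a clear inhibitor without them. Nothing shown gives a reason for this step.

As far as these compounds go, both chlorines leave together, so the share of each remains open. Also open, from the compounds shown here alone, is how a pyridyl ring or a cyclohexyl group on this nitrogen would compare with phenyl.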